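The source may hold more compounds than are shown below. What is called first, only, known or untested is meant among the compounds shown, and "the series" means these compounds.

Compound 1 `Cc1ccc(-c2cc(Cl)cc(C(=O)Nc3nn[nH]n3)n2)cc1`: 86%
Compound 2 `Cc1ccc(-c2cccc(C(=O)Nc3nn[nH]n3)n2)cc1`: 67%

Both numbers come from a functional assay on the whole organism with Rattus norvegicus as the target, at a dose of 1 mg/kg by the oral route; a lower number here means a weaker effect, a higher number a stronger effect of the compound at the dose given. Among the two compounds measured, compound 2 stands lowest, and its nearest neighbour is compound 1. Going by the values given here, the one step measured so far, a number 19 percentage points lower from compound 1 to compound 2 (beyond the scatter), is the only guide available: removing chloro from that aromatic carbon cost a modest but real amount of inhibition.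

Compound 3 `Cc1ccc(-c2cc(C)cc(C(=O)Nc3nn[nH]n3)n2)cc1` differs from compound 2 by methyl in place of hydrogen on an aromatic carbon. The carbon that receives the methyl is the same one that carries chloro in compound 1, so the step from compound 1 to compound 2 bears directly on this change, even though methyl is not chloro. It is therefore expected that compound 3 sits above compound 2, by a number 10 percentage points higher from compound 2 to compound 3 (within the scatter), a gain that may not reach the size seen with chloro. The estimate for compound 3 is 77%, with a range from 62% to 90%.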

Compound 3, a percentage reported as inhibition, in the whole organism at one dose (the size of the read-out at that dose, not a potency): 80%
For compound 3 the middle estimate is 3 percentage points below the measured one; low and high end bracket the measured number.
By their numbers in this assay, from the lowest: compound 2; then compounds 3 and 1 (each within the scatter of the next).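

In this assay, the position opposite the ring nitrogen responds to a second group as well: methyl in place of hydrogen gives a number 13 percentage points higher from compound 2 to compound 3 (beyond the scatter), so the gain over the unsubstituted ring is not peculiar to chloro. Exchanging the two groups gives a number 6 percentage points lower from compound 1 to compound 3 (within the scatter), so at this single dose methyl and chloro cannot be told apart at this position. Nothing measured on these compounds accounts for the gain that both groups give over hydrogen.

Going by these compounds, it remains open whether a larger or different group at this position, such as an ethyl chain, a methoxy group or an amine, would keep, raise or lose this level of inhibition. On these data alone, because each read-out is the size of the effect at one dose and not a potency, it also remains open whether methyl and chloro would still match at other doses.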